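A few compounds are considered here, and "the series" means these few. Any claim that something is new, unique, unknown or untested is made for them only; others in the source may bear on it.

In a functional assay on DU-145 cells (Homo sapiens) for cytotoxicity, read by trypan blue exclusion, with a stated time of 96 h (a lower number here means a stronger inhibitor, a higher number a weaker inhibitor), compound 1 (`O=S(=O)(/C=C/c1ccccc1)Nc1ccccc1`) gives 10000 nM, while compound 2 (`COc1cc(OC)c(/C=C/S(=O)(=O)Nc2ccc(OC)c(F)c2)c(OC)c1`) gives 200 nM, the lower of the two numbers and a gap well beyond the scatter. Compound 3 (`COc1cc(OC)c(/C=C/S(=O)(=O)Nc2ccc(OC)c(N)c2)c(OC)c1`) differs from compound 2 in one place: amino in place of fluoro on an aromatic carbon, ortho to a methoxy group. Among the measured compounds shown here, no measured pair shows this change, so the expectation rests on the structural change alone: a lower number in this assay, beyond the scatter. The expected change is a 6.7-fold lower number from compound 2 to compound 3 (0.82 log units; beyond the scatter). For compound 3 the estimated value is 30 nM, with an expected range of 6 nM to 150 nM.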

Compound 3, half-maximal inhibitory concentration: 5 nM
For compound 3 the middle estimate is 6.0-fold (0.78 log units) above the measured one, and the stated range ends above it.
By their numbers in this assay, from the lowest: compound 3; then compound 2; then compound 1.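

Among the compounds shown here, replacing fluoro with amino on the aromatic carbon ortho to a methoxy group gives a 40-fold lower number from compound 2 to compound 3 (1.60 log units; beyond the scatter) in this assay and shows that this one place strongly affects the number, even though only one heavy atom changes. The compound that already stood lowest could therefore still move much lower. No available evidence accounts for the size of this step.

The compounds shown leave open whether a hydroxyl, methylamino or acetamide group at this place would behave like amino. They also leave open how much the neighbouring methoxy group contributes.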